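This account rests on a few compounds, and the source may have more. Where it says the series, first, only, none or still open, it means among the compounds named here.

Going by the values given here, in an ADME assay on microsomes from liver (Homo sapiens) for metabolic stability (on this read-out higher numbers stand for fast clearance and lower numbers for slow clearance), compound 3 `O=C(N[C@H]1CN(S(=O)(=O)c2ccccc2)C[C@@H]1C(=O)NC[C@@H]1CCCN1)c1cc(-c2ccccc2Cl)on1` gives 9.7 mL.min-1.g-1, the only actual number among the compounds measured so far. Compound 1 `Cc1oc(-c2ccc(C(F)(F)F)cc2)nc1C(=O)N[C@H]1CN(S(=O)(=O)c2ccccc2)C[C@@H]1C(=O)N[C@H]1CCCNC1` is reported only as a limit, < 3 mL.min-1.g-1. Compound 2 `Cc1oc(-c2ccccc2Cl)nc1C(=O)N[C@H]1CN(S(=O)(=O)c2ccccc2)C[C@@H]1C(=O)N[C@H]1CCCNC1` is likewise reported only as a limit, < 3 mL.min-1.g-1.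

Compound 4 `O=CN1CCC[C@H](NC(=O)[C@H]2CN(S(=O)(=O)c3ccccc3)C[C@@H]2NC(=O)c2cc(-c3ccccc3Cl)on2)C1` departs from compound 3 in one place: a group of 8 heavy atoms (6 carbon, 1 nitrogen, 1 oxygen; one six-membered non-aromatic ring with 1 hetero atom) in place of a group of 6 heavy atoms (5 carbon, 1 nitrogen; one five-membered non-aromatic ring with 1 hetero atom), on an amide-type nitrogen. The (pyrrolidin-2-yl)methyl group leaves, and a group with a six-membered non-aromatic ring enters, on the same amide-type nitrogen.

Among the compounds with values here, the one measured step, a step that the two limits leave unreadable from compound 1 to compound 2, offers little guidance. It gives no readable size, and it concerns a change on an aromatic carbon rather than on that nitrogen. Within the data shown here, no measured step therefore supplies a size or a direction for this change, and the only numerical anchor is compound 3 with 9.7 mL.min-1.g-1.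

The expected step, a 1.1-fold lower number from compound 3 to compound 4 (0.03 log units; within the scatter), is accordingly none beyond the scatter, with a wide margin on either side. Compound 4 is estimated at 9 mL.min-1.g-1, with an expected range from 3.5 mL.min-1.g-1 to 24 mL.min-1.g-1.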

Compound 4, intrinsic clearance in microsomes: > 259 mL.min-1.g-1
Compound 4 ended at the assay's limit; the forecaster's own chance of this, stated with the estimate: 10%; middle value at least 28-fold (1.45 log units) away from the limit.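

Going by these compounds alone, the group on this amide-type nitrogen turns out to matter strongly in this assay, which the earlier compounds could not show, since the only step among them cannot be read and lies elsewhere on the molecule. Replacing the (pyrrolidin-2-yl)methyl group with the formyl-bearing six-membered ring gives an at least 26-fold higher number from compound 3 to compound 4 (1.42 log units; beyond the scatter). The value of compound 4 is a limit of the assay, not a number: the limit of > 259 mL.min-1.g-1 in this assay, at which 1 of the 4 values shown sits.

The compounds shown do not separate the parts of this change, so the step cannot be assigned to the ring size, the added carbonyl or the lost hydrogen-bond donor. As far as these compounds go, how a (piperidin-2-yl)methyl group or a 2-aminoethyl chain on the same amide-type nitrogen would read in this assay remains open.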